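The source may hold more compounds than are shown below. What is called first, only, known or untested is meant among the compounds shown, and "the series" means these compounds.

Working notes on the series, all read in a functional assay on HeLa cells (Homo sapiens) for antiproliferative activity, read by MTT assay, with a stated time of 48 h; a higher number here means a weaker inhibitor, a lower number a stronger inhibitor. Compound 1 `CC[C@@H](C)[C@H](NC(=O)c1ccc(Oc2nc3ccccc3nc2C)cc1)C(=O)OC` gives > 50000 nM, which is a limit of the assay. Compound 2 `CCCCCCCCCCCCNc1nc2ccccc2nc1Oc1ccc(C(=O)N[C@H](C(=O)OC)[C@H](C)CC)cc1` gives 40300 nM and compound 3 `CC[C@@H](C)[C@H](NC(=O)c1ccc(Oc2nc3ccccc3nc2NC(C)(C)C)cc1)C(=O)OC` gives 31900 nM, so these two stand level within the scatter. Compound 4 `CC(C)C[C@H](NC(=O)c1ccc(Oc2nc3ccccc3nc2NC(C)(C)C)cc1)C(=O)O` differs from compound 3 by 1-carboxy-3-methylbutyl in place of 1-(methoxycarbonyl)-2-methylbutyl on an amide-type nitrogen, with 1-carboxy-3-methylbutyl in place of 1-(methoxycarbonyl)-2-methylbutyl on an amide-type nitrogen. The measured steps, an at least 1.5-fold lower number from compound 1 to compound 3 (0.19 log units; that floor lies within the scatter) and a 1.3-fold lower number from compound 2 to compound 3 (0.10 log units; within the scatter), both lie within the scatter, and neither touches this group, so they give only weak guidance. The expected change is a 1.2-fold higher number from compound 3 to compound 4 (0.08 log units; within the scatter), with no step beyond the scatter anticipated. Compound 4 is estimated at 38000 nM, with an expected range of 15000 nM to 90000 nM.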

Compound 4, half-maximal inhibitory concentration: 39200 nM
Compound 4: middle estimate off by 1.0-fold (0.01 log units), on the low side, within the range that was stated.
By their numbers in this assay, from the lowest: compounds 3, 4 and 2 (each within the scatter of the next). At a limit, above all of these: compound 1.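

The earlier steps shown here left the group on the amide-type nitrogen untouched; here, in this assay, replacing 1-(methoxycarbonyl)-2-methylbutyl with 1-carboxy-3-methylbutyl gives a 1.2-fold higher number from compound 3 to compound 4 (0.09 log units; within the scatter). This single step changes both the ester to a carboxylic acid and the branching of the chain, and still no shift beyond the scatter appears. Compounds 2, 3 and 4 all lie close to the top of the readable range: the limit of > 50000 nM in this assay, at which 1 of the 4 values shown sits.

As far as these compounds go, whether the carboxylic acid and the branching would each act alone remains open, as a 1-(methoxycarbonyl)-3-methylbutyl group could show. Also open, from the compounds shown here alone, is whether an amine or a benzyl side chain here would move the number beyond the scatter.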